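A few compounds are considered here, and "the series" means these few. Any claim that something is new, unique, unknown or untested is made for them only; others in the source may bear on it.

Working notes on the series. Compound 1 `O=C1C(Nc2ccc(F)cc2)=CC(=O)c2ncccc21` is the reference point here. For the measured compounds named here, in a functional assay on the whole organism (aorta) with Rattus norvegicus as the target (on this read-out lower numbers stand for smaller maximal responses and higher numbers for larger maximal responses), compound 1 gives 79%, the lowest of the three numbers measured so far. Compound 2 `O=C1C(Nc2ccc(F)c(F)c2)=CC(=O)c2ncccc21` gives 92% in this assay, and compound 3 `O=C1C(Nc2ccc(F)cc2F)=CC(=O)c2ncccc21` gives 94% in this assay. The two steps out of compound 1 point the same way: a number 13 percentage points higher from compound 1 to compound 2 (beyond the scatter) and a number 15 percentage points higher from compound 1 to compound 3 (beyond the scatter), each of them a fluoro in place of hydrogen on an aromatic carbon.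

The compound now under consideration is compound 4 `O=C1C(Nc2ccc(Cl)cc2)=CC(=O)c2ncccc21`. Relative to compound 1 the change is chloro in place of fluoro on an aromatic carbon. Neither measured step is of this kind: both add a fluoro to the ring while keeping the fluoro of compound 1, whereas compound 4 exchanges that fluoro for chloro at the same place. Going by the values given here, no step in the set swaps one halogen for another, so the measured steps bear on the question only indirectly; they show that small changes on this ring have shifted the response by modest amounts and upward in both cases, but a swap rather than an addition need not follow.

The expectation for compound 4 in this assay is therefore a step of about a number 5 percentage points higher from compound 1 to compound 4 (within the scatter), small and not clearly beyond the scatter. Compound 4 is estimated at 84%, with a range from 70% to 98%.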

Compound 4, largest response reached (Emax), in percent of the reference or control that the assay uses: 86%
Compound 4: the middle estimate sits 2 percentage points below what was measured, and the stated range covers the measured number.
By their numbers in this assay, from the lowest: compounds 1, 4, 2 and 3 (each within the scatter of the next, the first and the last beyond it).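

For the compounds shown here, this is the first exchange of one halogen for another: at the place para to a large group, chloro in place of fluoro gives a number 7 percentage points higher from compound 1 to compound 4 (within the scatter) in this assay and so, unlike the two added fluoro steps, does not move the read-out beyond the scatter. On the present numbers, this place therefore accepts chloro for fluoro, one heavy atom for one, with no change in hydrogen-bond donors, hydrogen-bond acceptors or net charge and no resolved change in the maximal response. No measurement among the data shown accounts for this result or links it to any property of the two halogens.

Open, going by these compounds, is how far this tolerance extends at the same place, for example to bromo, methoxy, trifluoromethyl, an amine or a carboxylic acid, and whether a result in this assay would stay within the scatter for any of them. Going by these compounds alone, also open is whether a second halogen on the ring of compound 4 would raise the number as the added fluoro did on the ring of compound 1, since no step starting from compound 4 stands.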